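Amide sulfones: nitro to amino on compound 3

The compounds below may be only part of what the source reports. "The series", "measured", "known", "first", "only" and "open" are said of these compounds alone.

Compound 1 `COc1ccc(CS(=O)(=O)/C=C/c2c(OC)cccc2OC)cc1[N+](=O)[O-]` gives 5460 nM in a functional assay on MDA-MB-468 cells (Homo sapiens) for cytotoxicity, read by MTT assay, with a stated time of 72 h; a higher number here means a weaker inhibitor of growth, a lower number a stronger inhibitor of growth. Compound 2 `COc1ccc(CS(=O)(=O)CC(=O)Nc2c(C)cc(C)cc2C)cc1[N+](=O)[O-]` reaches only a limit of this assay, > 30000 nM. Compound 3 `COc1ccc(CS(=O)(=O)CC(=O)Nc2ccccc2)cc1[N+](=O)[O-]` likewise reaches only a limit, > 30000 nM.

Within the data shown here, compound 3 therefore stands at the ceiling of this assay, with no number of its own; the vinyl sulfone compound 1 is the one measured value in the set. Among the measured compounds shown here, the single step between measured compounds, phenyl in place of 2,4,6-trimethylphenyl on an amide-type nitrogen, is a step that the two limits leave unreadable from compound 2 to compound 3, since both ends sit at the limit of > 30000 nM in this assay, at which 2 of the 3 values shown sit.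

Compound 4 `COc1ccc(CS(=O)(=O)CC(=O)Nc2ccccc2)cc1N` differs from compound 3 by amino in place of nitro on an aromatic carbon. For the measured compounds named here, no measured step touches this change: the nitro group is kept throughout compounds 1 to 3, and the one recorded step concerns the amide substituent and is unreadable. There is thus no basis for expecting a readable shift in this assay from compound 3 to compound 4, and the likeliest outcome is that compound 4 again returns a limit.

The step from compound 3 to compound 4 is estimated as a number no higher from compound 3 to compound 4 (the limit leaves the size open). Compound 4 is estimated at 30000 nM, with a range from 8000 nM to 100000 nM.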

Compound 4, concentration for 50% growth inhibition: > 30000 nM
Compound 4: only a limit was reported; the forecaster's own chance of this, stated with the estimate: 65%; the middle value sits exactly at the limit.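

Compound 3 and compound 4 both reach only a limit in this assay, so amino in place of nitro yields no readable step: the limit of > 30000 nM in this assay, at which 3 of the 4 values shown sit.

The compounds shown leave open how far amino in place of nitro on an aromatic carbon shifts growth inhibition, and what actual value compound 2, compound 3 or compound 4 would take.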